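This account rests on a few compounds, and the source may have more. Where it says the series, first, only, none or still open, it means among the compounds named here.

In a functional assay on HCT-116 cells (Homo sapiens), read by MTT assay, with a stated time of 72 h (on this read-out higher numbers stand for weaker inhibition and lower numbers for stronger inhibition), compound 1 `COc1ncnc2c1c(-c1ccsc1)cn2[C@@H]1O[C@H](CO)[C@@H](O)[C@H]1O` gives 120 nM. Compound 2 `COc1nc(N)nc2c1c(-c1ccsc1)cn2[C@@H]1O[C@H](CO)[C@@H](O)[C@H]1O` gives > 20000 nM, which is a limit of this assay and not a number. Compound 3 `O=c1[nH]cnc2c1c(-c1ccco1)cn2[C@@H]1O[C@H](CO)[C@@H](O)[C@H]1O` gives 18300 nM.

Compounds 1 and 2 share a core and differ in one change, (amino in place of hydrogen on an aromatic carbon). That change brought an at least 160-fold higher number from compound 1 to compound 2 (2.22 log units; beyond the scatter). As far as these compounds go, its true size is unknown, since compound 2 sits at the limit of > 20000 nM in this assay, at which 1 of the 3 values shown sits.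

Compound 3 has a different core from compound 1; the difference between the two cores is not broken down here. Compound 3 stands the highest of the two numbers, far from compound 1.

Compound 4 `Nc1nc2c(c(-c3ccco3)cn2[C@@H]2O[C@H](CO)[C@@H](O)[C@H]2O)c(=O)[nH]1` is not yet measured. It comes from compound 3 by the same kind of change, (amino in place of hydrogen on an aromatic carbon); the surroundings differ only in that the amino group is meta to a group of 1 heavy atom rather than meta to a methoxy group (2 heavy atoms). For compound 4 a step of a 4.4-fold higher number from compound 3 to compound 4 (0.64 log units; beyond the scatter) in this assay is expected, resting on the step of an at least 160-fold higher number from compound 1 to compound 2 (2.22 log units; beyond the scatter) and on the value of compound 3, 18300 nM. Compound 4 is therefore estimated at 80000 nM, most likely reported only as a limit.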

Compound 4, half-maximal inhibitory concentration: > 20000 nM
Compound 4: a limit, no number; the forecaster's own chance of this, stated with the estimate: 85%; the middle value is on the limit's open side.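

In this assay compound 4 gives > 20000 nM, which is a limit of the assay and not a number. On the core of compound 3, the amino group therefore yields only a floor, an at least 1.0-fold higher number from compound 3 to compound 4 (0.03 log units; that floor lies within the scatter), so the result fits a weakening on this core as well but does not prove one, and the comparison with the first case reads: the same change on two cores in this assay, an at least 160-fold higher number (2.22 log units; beyond the scatter) from compound 1 to compound 2 and an at least 1.0-fold higher number (0.03 log units; that floor lies within the scatter) from compound 3 to compound 4; the limit leaves it open whether they differ The two cores thus agree in that neither amino compound gives a number within the assay's range, but the true size of the change stays unknown on both, and nothing shows that it carries over with the same size, since both amino compounds sit at one ceiling: the limit of > 20000 nM in this assay, at which 2 of the 4 values shown sit.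

The compounds shown leave open how the change would read on a core whose starting value lies far enough from the limit for a full step to be measured. They also leave open whether a smaller group between the two ring nitrogen atoms, such as a methyl group or a fluorine atom, would keep the value of compound 1.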